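This account rests on a few compounds, and the source may have more. Where it says the series, first, only, none or still open, it means among the compounds named here.

Values measured in a functional assay on brain (Rattus norvegicus, strain Wistar) for inhibition; on this read-out lower numbers stand for stronger inhibition and higher numbers for weaker inhibition
Compound 1 `Cc1[nH]c(=O)n(C2CCCCC2)c1-c1ccccc1` gives 47600 nM here
Compound 2 `CCCCc1ccc(-c2c(C)[nH]c(=O)n2C2CCCCC2)cc1` gives 27100 nM here
Compound 3 `Cc1[nH]c(=O)n(C2CCCCC2)c1-c1ccc(CC(C)C)cc1` gives 10900 nM here

Compound 3 holds the lowest number of the three, and its steps to both other compounds lie beyond the scatter. The unmeasured compound 4 `CCCCCCc1ccc(-c2c(C)[nH]c(=O)n2C2CCCCC2)cc1` differs from it by pentyl in place of isopropyl on a saturated chain carbon bound to an aromatic carbon with pentyl in place of isopropyl on a saturated chain carbon bound to an aromatic carbon. Cut one bond further out, the same difference reads isobutyl to hexyl.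

For the measured compounds named here, three measured steps bear on this. Butyl in place of hydrogen gave a 1.8-fold lower number from compound 1 to compound 2 (0.24 log units; within the scatter) and isobutyl in place of hydrogen gave a 4.4-fold lower number from compound 1 to compound 3 (0.64 log units; beyond the scatter) while isopropyl in place of propyl gave a 2.5-fold lower number from compound 2 to compound 3 (0.40 log units; beyond the scatter) at the same place as the coming change. Hexyl is longer than any chain measured so far, and like the butyl of compound 2 it has no branch. In this assay the expected change is small and towards a higher number. The estimated size is a 1.7-fold higher number from compound 3 to compound 4 (0.22 log units; within the scatter) and so stays within the scatter. The estimate for compound 4 is 18000 nM within an expected range of 6000 nM to 50000 nM on this read-out.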

Compound 4, half-maximal inhibitory concentration: 13700 nM
For compound 4 the middle estimate is 1.3-fold (0.12 log units) above the measured one, and the stated range covers the measured number.
By their numbers in this assay, from the lowest: compounds 3, 4, 2 and 1 (each within the scatter of the next, the first and the last beyond it).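

In this assay, the unbranched hexyl of compound 4 cannot be told apart from the branched isobutyl of compound 3 (a 1.3-fold higher number from compound 3 to compound 4 (0.10 log units; within the scatter)), so among these chains a branch is not required to reach this range. Hexyl also cannot be told apart from the butyl of compound 2 (a 2.0-fold lower number from compound 2 to compound 4 (0.30 log units; within the scatter)), so adding ethyl to that chain produces no readable change. Against the hydrogen of compound 1, hexyl gives a step beyond the scatter (a 3.5-fold lower number from compound 1 to compound 4 (0.54 log units; beyond the scatter)), making it the second chain to do so after isobutyl, whereas butyl stays within the scatter.

Nothing available explains why these chains differ so little. Still open, going by these compounds, is whether an octyl chain, or a butyl chain carrying an amine or a carboxylic acid, would move the number beyond the scatter of compound 3.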